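Chloro Substitution Across Two Related Cores

The source may report more compounds than this note shows. Statements on the series, on what has been measured and on what is new or still open speak of the compounds shown alone.

Compound 1 `ClCc1ccccc1Cn1cnc2c(Cl)nc(Cl)nc21`, compound 2 `ClCc1ccccc1Cn1cnc2c(Cl)ncnc21` and compound 3 `ClCc1ccccc1Cn1cnc2ncnc(Cl)c21` were tested in a functional assay on BT-549 cells (Homo sapiens) for cytotoxicity, read by sulforhodamine B assay, with a stated time of 48 h; on this read-out lower numbers stand for stronger inhibition of growth and higher numbers for weaker inhibition of growth. In this assay compound 1 gives 1470 nM, compound 2 gives 5490 nM and compound 3 gives 6020 nM. Compound 1 differs from compound 2 by chloro in place of hydrogen on an aromatic carbon, and this change gave a 3.7-fold lower number from compound 2 to compound 1 (0.57 log units; beyond the scatter). The difference between the core of compound 2 and the core of compound 3 is not broken down here; their values in this assay lie within the scatter of each other. Compound 4 `ClCc1ccccc1Cn1cnc2nc(Cl)nc(Cl)c21` has not yet been measured; it differs from compound 3 by chloro in place of hydrogen on an aromatic carbon, the same change as that from compound 2 to compound 1. In this assay compound 4 is expected to show a 3.5-fold lower number from compound 3 to compound 4 (0.55 log units; beyond the scatter). That expectation rests on the step of a 3.7-fold lower number from compound 2 to compound 1 (0.57 log units; beyond the scatter) seen with compound 2 and compound 1. The estimate for compound 4 is 1700 nM, expected to fall between 800 nM and 3600 nM.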

Compound 4, concentration for total growth inhibition: 3090 nM
Compound 4: middle estimate off by 1.8-fold (0.26 log units), on the low side; the range from low to high includes it.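

In this assay, chloro in place of hydrogen on an aromatic carbon gave a 1.9-fold lower number from compound 3 to compound 4 (0.29 log units; within the scatter). Set beside the earlier step, the change does not differ measurably between the two cores: the same change on two cores in this assay, a 3.7-fold lower number (0.57 log units; beyond the scatter) from compound 2 to compound 1 and a 1.9-fold lower number (0.29 log units; within the scatter) from compound 3 to compound 4, 1.9-fold (0.28 log units) apart, within the scatter of two such steps. The result is compatible with the change carrying over at a similar size, but it does not establish this, as the step on the core of compound 3 does not by itself stand clear of the scatter and two pairs set no rule for other cores.

The compounds shown carry only chloro or hydrogen on the ring carbon between two ring nitrogen atoms, so what an amine, a methoxy group or a longer chain would do there remains open. Also open, as far as these compounds go, is how the change behaves outside this assay.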